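Chloro for methoxy: extending the series from compound 3

A few compounds are considered here, and "the series" means these few. Any claim that something is new, unique, unknown or untested is made for them only; others in the source may bear on it.

Measured so far:
compound 1 `Cc1ccc(C(C)NC(=O)/N=C(\N)NCCCc2sc(N)nc2C)cc1` — 30.9 nM
compound 2 `Cc1nc(N)sc1CCCN/C(N)=N/C(=O)NC(C)c1cccs1` — 63.1 nM
compound 3 `COc1ccc(C(C)NC(=O)/N=C(\N)NCCCc2sc(N)nc2C)cc1` — 37.2 nM

In an assay on membranes from Sf9 cells for displacement of a labelled ligand from histamine H2 receptor (Homo sapiens), read by scintillation counting, with a stated time of 60 min (on this read-out lower numbers stand for stronger inhibition and higher numbers for weaker inhibition), compound 3 holds the second highest of the three numbers. Going by the values given here, its nearest neighbour is compound 1, a 1.2-fold higher number from compound 1 to compound 3 (0.08 log units; within the scatter); the furthest is compound 2, a 1.7-fold lower number from compound 2 to compound 3 (0.23 log units; within the scatter); the only step beyond the scatter is a 2.0-fold higher number from compound 1 to compound 2 (0.31 log units; beyond the scatter).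

Compound 4 `Cc1nc(N)sc1CCCN/C(N)=N/C(=O)NC(C)c1ccc(Cl)cc1` carries chloro in place of methoxy on an aromatic carbon. The step that bears on it is a 1.2-fold higher number from compound 1 to compound 3 (0.08 log units; within the scatter), an exchange at the same aromatic carbon that stayed within the scatter. Among the compounds with values here, no measured step introduces chloro anywhere, so the expectation rests on that one step alone: no change beyond the scatter in this assay is expected, and the step of a 1.2-fold lower number from compound 3 to compound 4 (0.07 log units; within the scatter) is estimated accordingly. Compound 4 is therefore expected to give about 32 nM, with a range of 12 nM to 85 nM.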

Compound 4, inhibition constant: 46.8 nM
Estimate against measurement, compound 4: 1.5-fold (0.17 log units) below, within the range that was stated.
By their numbers in this assay, from the lowest: compounds 1, 3, 4 and 2 (each within the scatter of the next, the first and the last beyond it).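

Chloro for methoxy at this aromatic carbon gives a 1.3-fold higher number from compound 3 to compound 4 (0.10 log units; within the scatter) and chloro for methyl gives a 1.5-fold higher number from compound 1 to compound 4 (0.18 log units; within the scatter) so methyl, methoxy and chloro at this place all lie within the scatter of one another. Replacing thiophen-2-yl with 4-chlorophenyl gives a 1.3-fold lower number from compound 2 to compound 4 (0.13 log units; within the scatter) and this leaves compound 4 within the scatter of compound 2 as well. No evidence on the cause of these values is available.

As far as these compounds go, whether an amine, a hydroxyl or a carboxylic acid at this place would give a step beyond the scatter remains open.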